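The source may report more compounds than this note shows. Statements on the series, on what has been measured and on what is new or still open speak of the compounds shown alone.

Compound 1, `O=C(Nc1cccc(-n2cc(-c3ccncc3)c(-c3ccc(Cl)c(O)c3)n2)c1)Nc1cccc(C(F)(F)F)c1`: 4260 nM
Compound 2, `COc1cc(-c2nn(-c3cccc(NC(=O)Nc4cc(C(F)(F)F)cc(C(F)(F)F)c4)c3)cc2-c2ccncc2)ccc1Cl`: 1230 nM
Compound 3, `COc1cc(-c2nn(-c3cccc(NC(=O)c4cccc(C(F)(F)F)c4)c3)cc2-c2ccncc2)ccc1Cl`: 3000 nM

All three were tested in a functional assay on SF-295 cells (Homo sapiens) for inhibition, read by sulforhodamine B assay, with a stated time of 48 h; a lower number here means a stronger inhibitor of growth, a higher number a weaker inhibitor of growth. On these numbers compound 3 stands second highest; its nearest neighbour is compound 1, whose value lies within the usual scatter of it, while compound 2, with the lowest number, lies beyond the scatter from it. Compound 4, `COc1cc(-c2nn(-c3cccc(NC(=O)c4ccc(Cl)c(C(F)(F)F)c4)c3)cc2-c2ccncc2)ccc1Cl`, has not yet been measured. It differs from compound 3 in one place: chloro in place of hydrogen on an aromatic carbon. Going by the values given here, no pair of measured compounds isolates such a change, so nothing here shows how much it matters. The step that the estimate means, a 1.4-fold lower number from compound 3 to compound 4 (0.15 log units; within the scatter), is expected to be small, probably no larger than the scatter, with a slight lean toward a lower number. Compound 4 is therefore estimated at 2100 nM, between 900 nM and 4800 nM.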

Compound 4, concentration for total growth inhibition: 17300 nM
Estimate against measurement, compound 4: 8.2-fold (0.92 log units) below; measured number above the stated range.
By their numbers in this assay, from the lowest: compound 2; then compounds 3 and 1 (each within the scatter of the next); then compound 4.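

In this assay chloro in place of hydrogen gives a 5.8-fold higher number from compound 3 to compound 4 (0.76 log units; beyond the scatter) and is therefore no neutral swap. At this position, ortho to a trifluoromethyl group and para to a large group, one added chlorine atom makes the compound a clearly weaker inhibitor of growth, at least in this single pair. No measurement at hand explains the loss. As far as these compounds go, whether any group placed here would do the same stays open: fluoro, methyl or an amine at this carbon could tell whether the loss belongs to chloro alone.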